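This account rests on a few compounds, and the source may have more. Where it says the series, first, only, none or still open, it means among the compounds named here.

Measured so far:
- Compound 1 `C/C(=C\CC/C(C)=C/CC[C@@H]1[C@@]2(C)CCC(=O)C(C)(C)[C@H]2CC[C@@]1(C)O)CC/C=C(\C)C(=O)OCc1cn(C[C@@H]2O[C@H](n3ccc(=O)[nH]c3=O)C[C@H]2O)nn1`: 26300 nM
- Compound 2 `C#CCOC(=O)/C(C)=C/CC/C(C)=C/CC/C(C)=C/CC[C@@H]1[C@@]2(C)CCC(=O)C(C)(C)[C@H]2CC[C@@]1(C)O`: 114000 nM
- Compound 3 `C/C(=C\CC/C(C)=C/CC[C@@H]1[C@@]2(C)CCC(=O)C(C)(C)[C@H]2CC[C@@]1(C)O)CC/C=C(\C)C(=O)OCc1cn([C@@H]2C[C@@H](n3cc(C)c(=O)[nH]c3=O)O[C@H]2CO)nn1`: 38000 nM

In a functional assay on MDA-MB-231 cells (Homo sapiens) for antiproliferative activity, read by MTT assay, with a stated time of 48 h (a lower number here means a stronger inhibitor, a higher number a weaker inhibitor), compound 2 gives 114000 nM, the highest of the three numbers, which makes it the weakest inhibitor of the three. Compound 4 `C/C(=C\CC/C(C)=C/CC[C@@H]1[C@@]2(C)CCC(=O)C(C)(C)[C@H]2CC[C@@]1(C)O)CC/C=C(\C)C(=O)OCc1cn(-c2ccccc2F)nn1` differs from compound 2 by one change: 1-(2-fluorophenyl)-1H-1,2,3-triazol-4-yl in place of ethynyl on a saturated chain carbon bound to an oxygen next to a carbonyl group. In words, 1-(2-fluorophenyl)-1H-1,2,3-triazol-4-yl stands in place of ethynyl on a saturated chain carbon bound to an oxygen next to a carbonyl group. Compound 1 at 26300 nM and compound 3 at 38000 nM also carry a triazole ring, and both sit lower than compound 2. A similar drop, beyond the scatter, is therefore expected, as an estimated step of a 3.3-fold lower number from compound 2 to compound 4 (0.51 log units; beyond the scatter). The estimate for compound 4 is 35000 nM, with an expected range of 12000 nM to 90000 nM.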

Compound 4, half-maximal inhibitory concentration: > 150000 nM
Compound 4 was reported as a limit; the forecaster's own chance of this, stated with the estimate: 10%; middle value at least 4.2-fold (0.63 log units) from the limit.
By their numbers in this assay, from the lowest: compounds 1 and 3 (each within the scatter of the next); then compound 2. At a limit, above all of these: compound 4.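

In this assay, compound 4 is reported only as a limit: the limit of > 150000 nM in this assay, at which 1 of the 4 values shown sits. The step reads as an at least 1.3-fold higher number from compound 2 to compound 4 (0.11 log units; that floor lies within the scatter), so a triazole ring at this position does not by itself give a lower number. The lower numbers of compound 1 and compound 3 therefore cannot be credited to the triazole ring alone, and the group that ring carries also matters. The compounds shown leave open how a triazole ring carrying an amine, a carboxylic acid or a plain phenyl in place of the 2-fluorophenyl would behave.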